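Benzoyl cap swap on a trimethyllysine peptide series

The source may report more compounds than this note shows. Statements on the series, on what has been measured and on what is new or still open speak of the compounds shown alone.

Values in an assay on isolated protein for displacement of a labelled ligand from Chromobox protein homolog 7 (Homo sapiens), read by fluorescence polarization, with a stated time of 15 min; a higher number here means a weaker inhibitor, a lower number a stronger inhibitor:
- compound 1 `CC(C)C[C@H](NC(=O)[C@H](C)NC(=O)c1ccccc1)C(=O)N[C@@H](CCCC[N+](C)(C)C)C(=O)N[C@@H](CO)C(N)=O`: 57000 nM
- compound 2 `CC(C)C[C@H](NC(=O)[C@H](C)NC(=O)CNC(=O)c1ccccc1)C(=O)N[C@@H](CCCC[N+](C)(C)C)C(=O)N[C@@H](CO)C(N)=O`: 58000 nM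
- compound 3 `Cc1ccc(S(=O)(=O)NCC(=O)N[C@@H](C)C(=O)N[C@@H](CC(C)C)C(=O)N[C@@H](CCCC[N+](C)(C)C)C(=O)N[C@@H](CO)C(N)=O)cc1`: 34000 nM

Compound 2 carries the highest of the three numbers in this assay, but its nearest neighbour compound 1 sits a 1.0-fold higher number from compound 1 to compound 2 (0.01 log units; within the scatter) from it, and compound 3, the furthest, sits only a 1.7-fold lower number from compound 2 to compound 3 (0.23 log units; within the scatter) away; neither separation clears the scatter, so the three compounds read as one level.

Compound 4 `CC(C)C[C@H](NC(=O)[C@H](C)NCc1ccc(C(=O)O)cc1)C(=O)N[C@@H](CCCC[N+](C)(C)C)C(=O)N[C@@H](CO)C(N)=O` differs from compound 2 in one place: 4-carboxybenzyl in place of (benzamidomethyl)carbonyl on an amine nitrogen. The 4-carboxybenzyl group replaces the acyl cap with a benzylic substituent bearing a carboxylic acid, and the intervening glycine unit is lost.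

For the measured compounds named here, the steps that bear on this are those at the same end of the chain: a 1.0-fold higher number from compound 1 to compound 2 (0.01 log units; within the scatter), a 1.7-fold lower number from compound 1 to compound 3 (0.22 log units; within the scatter) and a 1.7-fold lower number from compound 2 to compound 3 (0.23 log units; within the scatter). All three exchange one cap for another, including a change of cap size and of sulfonyl for acyl, and none moves the number beyond the scatter. Nothing measured here separates an acylated from a benzylated amine nitrogen, so the expectation rests on the general insensitivity of this position.

Accordingly compound 4 is expected to sit at about the common level, with a step of a 1.2-fold lower number from compound 2 to compound 4 (0.06 log units; within the scatter), giving an estimate of 50000 nM within 20000 nM to 150000 nM.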

Compound 4, half-maximal inhibitory concentration: > 2000000 nM
Compound 4: a limit, no number; the forecaster's own chance of this, stated with the estimate: 20%; at least 40-fold (1.60 log units) between middle value and limit.
By their numbers in this assay, from the lowest: compounds 3, 1 and 2 (each within the scatter of the next). At a limit, above all of these: compound 4.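

Compound 4 gives no number in this assay, only a limit: the limit of > 2000000 nM in this assay, at which 1 of the 4 values shown sits.

The position that looked indifferent across the caps of compounds 1, 2 and 3 does respond to this change: the step of an at least 34-fold higher number from compound 2 to compound 4 (1.53 log units; beyond the scatter) and the step of an at least 35-fold higher number from compound 1 to compound 4 (1.54 log units; beyond the scatter) are both large and beyond the scatter, whereas every earlier step stayed within it. Compounds 1, 2 and 3 all carry a carbonyl on this amine nitrogen, while compound 4 has 4-carboxybenzyl there, and the tolerance seen so far therefore holds only among caps attached through a carbonyl.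

Compound 4 removes that carbonyl and brings in a carboxylic acid in a single step, and the compounds shown do not tell which of the two accounts for the loss, nor how large the step really is beyond the limit. A plain benzyl group on this nitrogen, or a 4-carboxybenzoyl cap that keeps the carbonyl together with the carboxylic acid, would separate the two, and a methyl ester or a primary amide in place of the carboxylic acid would test the acid itself.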